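Swapping one trimethoxyphenyl pattern for another

This account rests on a few compounds, and the source may have more. Where it says the series, first, only, none or still open, it means among the compounds named here.

Values so far in a functional assay on HepG2 cells (Homo sapiens) for antiproliferative activity, read by sulforhodamine B assay, with a stated time of 48 h (on this read-out lower numbers stand for stronger inhibition and higher numbers for weaker inhibition), read:
compound 1 `COc1ccc(OC)c(/C=C/C(=O)/C=C(O)/C=C/c2cc(OC)ccc2OC)c1` gives 5560 nM
compound 2 `COc1cc(OC)c(C=C(C(=O)/C=C/c2cccc(OC)c2OC)C(=O)/C=C/c2cccc(OC)c2OC)c(OC)c1` gives 300 nM
compound 3 `COc1cccc(/C=C/C(=O)C(=Cc2ccc(O)c(F)c2)C(=O)/C=C/c2cccc(OC)c2OC)c1OC` gives 220 nM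

Compound 2 (300 nM) sits within the scatter of compound 3 (220 nM), while compound 1 (5560 nM) shows a higher number than either. The change to compound 4 `COc1cccc(/C=C/C(=O)C(=Cc2ccc(OC)c(OC)c2OC)C(=O)/C=C/c2cccc(OC)c2OC)c1OC` is 2,3,4-trimethoxyphenyl in place of 2,4,6-trimethoxyphenyl on a double-bonded chain carbon bound to a double-bonded chain carbon and reads 2,3,4-trimethoxyphenyl in place of 2,4,6-trimethoxyphenyl on a double-bonded chain carbon bound to a double-bonded chain carbon. For the measured compounds named here, the one measured step at that place is a 1.4-fold lower number from compound 2 to compound 3 (0.13 log units; within the scatter) and it lies within the scatter, with 3-fluoro-4-hydroxyphenyl entering. Going by the values given here, no measured step exchanges one trimethoxyphenyl pattern for another. Going by compound 3 (220 nM), no step beyond the scatter is expected in this assay and no direction is favoured. The estimated step is a 1.1-fold lower number from compound 2 to compound 4 (0.03 log units; within the scatter) and it stays inside the scatter. The estimated value for compound 4 is 280 nM with an expected range from 110 nM to 700 nM on repeated measurement.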

Compound 4, half-maximal inhibitory concentration: 240 nM
Compound 4: the middle estimate sits 1.2-fold (0.07 log units) above what was measured, within the range that was stated.
By their numbers in this assay, from the lowest: compounds 3, 4 and 2 (each within the scatter of the next); then compound 1.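

In this assay, the exchange of 2,4,6-trimethoxyphenyl for 2,3,4-trimethoxyphenyl on a double-bonded chain carbon bound to a double-bonded chain carbon gives a 1.3-fold lower number from compound 2 to compound 4 (0.10 log units; within the scatter), so a direct swap between two groups with the same atoms now stands measured and stays inside the scatter. The comparison of 2,3,4-trimethoxyphenyl with 3-fluoro-4-hydroxyphenyl, a 1.1-fold higher number from compound 3 to compound 4 (0.04 log units; within the scatter), is also within the scatter, and the three groups shown at this place cannot be told apart on this read-out. Nothing available explains why these groups read alike.

The compounds shown leave open whether this place would keep its reading with a phenyl ring carrying an amine or a carboxylic acid. They also leave open what a pyridine ring or a simple methyl group would do there.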